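Swapping the ortho bromo for methyl on the benzyl ether

A few compounds are considered here, and "the series" means these few. Any claim that something is new, unique, unknown or untested is made for them only; others in the source may bear on it.

Measured so far in an assay on isolated protein for inhibition of protein tyrosine phosphatase type IVA 3 (Homo sapiens), tested at 5 ug/mL; on this read-out higher numbers stand for more inhibition at the one concentration tested (going by the name of the read-out) and lower numbers for less inhibition:
compound 1 `COc1ccccc1COc1ccccc1/C=C/C=C1\SC(=S)NC1=O` gives 78.8%
compound 2 `COc1ccccc1/C=C/C=C1\SC(=S)NC1=O` gives 41.7%
compound 3 `O=C1NC(=S)S/C1=C\C=C\c1ccccc1OCc1ccccc1Br` gives 63.1%

Compound 3 stands second highest of the three in this assay: compound 1 lies beyond the scatter above it, compound 2 beyond the scatter below it. The unmeasured compound 4 `Cc1ccccc1COc1ccccc1/C=C/C=C1\SC(=S)NC1=O` differs from compound 3 in one place: methyl in place of bromo on an aromatic carbon.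

Among the compounds with values here, two measured steps bear on this. The step of a number 15.7 percentage points lower from compound 1 to compound 3 (beyond the scatter) shows that the group on that aromatic carbon matters, with methoxy giving the higher number. The step of a number 21.4 percentage points higher from compound 2 to compound 3 (beyond the scatter) shows that the 2-bromophenyl group as a whole adds a modest amount over hydrogen, while a number 37.1 percentage points lower from compound 1 to compound 2 (beyond the scatter) shows the 2-methoxyphenyl group adds a large amount. Within the data shown here, no measured step puts methyl on that carbon, so the size of the change is open; a methyl is expected to sit somewhere between bromo and methoxy, giving a small rise in this assay for compound 4, with a result within the scatter also plausible.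

Compound 4 is therefore expected to give about 68% in this assay, in a range from 52% to 84%, a step of a number 4.9 percentage points higher from compound 3 to compound 4 (within the scatter) as the estimate.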

Compound 4, a percentage reported as inhibition, at one concentration (the size of the read-out at that concentration, not a potency): 52.8%
The estimate for compound 4 lay 15.2 percentage points above the measured number; the measured number falls inside the stated range.
By their numbers in this assay, from the lowest: compound 2; then compound 4; then compound 3; then compound 1.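

The group on this aromatic carbon matters even when the swap is between two single heavy atoms, neither of which counts as a hydrogen-bond donor or acceptor: in this assay there is a number 10.3 percentage points lower from compound 3 to compound 4 (beyond the scatter), and a number 26 percentage points lower from compound 1 to compound 4 (beyond the scatter). Methyl therefore does not fall between bromo and methoxy, and the three groups read in the order methoxy, bromo, methyl, each separated from the others beyond the scatter. The 2-methylphenyl group still gives a gain over hydrogen, with a number 11.1 percentage points higher from compound 2 to compound 4 (beyond the scatter), so all three substituted benzyl ethers stand above compound 2, the methyl one by the least; nothing in the evidence at hand accounts for this order.

The compounds shown leave open where a plain benzyl ether, with hydrogen on this carbon, would fall, and how a hydroxyl, an amine or a carboxylic acid would read there. They also leave open whether the same order of groups would hold on another carbon of that ring, and, with one concentration tested, how it would carry over to potency.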